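The source may report more compounds than this note shows. Statements on the series, on what has been measured and on what is new or still open speak of the compounds shown alone.

Measured so far:
compound 1, `Nc1scc(CN2CCN(c3cc(Cl)cc(Cl)c3)CC2)c1C(=O)c1ccc(Cl)cc1`: -22%
compound 2, `Nc1scc(CN2CCN(c3cccnc3)CC2)c1C(=O)c1ccc(Cl)cc1`: 3.4%
compound 3, `Nc1scc(CN2CCN(c3cc(F)cc(F)c3)CC2)c1C(=O)c1ccc(Cl)cc1`: -5%

In a functional assay on CHO cells with adenosine receptor A1 (Homo sapiens) as the target, read by cAMP accumulation and immunoassay, with a stated time of 6 min, tested at 0.1 uM (a lower number here means a stronger effect, a higher number a weaker effect of the compound at the concentration tested), compound 1 stands lowest of the three, and its steps to compound 3 and to compound 2 are both beyond the scatter. Compound 4, `Nc1scc(CN2CCN(c3c(F)cccc3F)CC2)c1C(=O)c1ccc(Cl)cc1`, differs from compound 1 in one place: 2,6-difluorophenyl in place of 3,5-dichlorophenyl on an amine nitrogen in a ring. The closest measured step is a number 17 percentage points higher from compound 1 to compound 3 (beyond the scatter), where 3,5-difluorophenyl replaced 3,5-dichlorophenyl at the same place; the other is a number 25.4 percentage points higher from compound 1 to compound 2 (beyond the scatter). Among the compounds with values here, both moves away from 3,5-dichlorophenyl gave a modest rise, so a rise of similar size is expected here, though 2,6-difluorophenyl has no measured counterpart. Compound 4 is therefore estimated at -5%, with a likely range of -22% to 12%, a step of a number 17 percentage points higher from compound 1 to compound 4 (beyond the scatter) expected.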

Compound 4, a percentage reported as activity, at one concentration (the size of the read-out at that concentration, not a potency): -23%
Compound 4: middle estimate off by 18 percentage points, on the high side, and the stated range ends above it.
By their numbers in this assay, from the lowest: compounds 4 and 1 (each within the scatter of the next); then compounds 3 and 2 (each within the scatter of the next).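

Read in this assay at this place on an amine nitrogen in a ring, leaving 3,5-dichlorophenyl need not raise the number, since the outcome is a number 1 percentage points lower from compound 1 to compound 4 (within the scatter) and not a rise. Where the two fluorines stand also counts, as 3,5-difluorophenyl and 2,6-difluorophenyl are separated by a number 18 percentage points lower from compound 3 to compound 4 (beyond the scatter) even though both carry the same halogen. Pyridin-3-yl stays apart, with a number 26.4 percentage points lower from compound 2 to compound 4 (beyond the scatter) as the step.

No measurement shown gives a reason for these differences. Still open, from the compounds shown here alone, is whether 2,6-dichlorophenyl, an unsubstituted phenyl or a phenyl with a single fluorine would read like compound 4.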